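A few compounds are considered here, and "the series" means these few. Any claim that something is new, unique, unknown or untested is made for them only; others in the source may bear on it.

Measured compounds, all tested in a functional assay on PC-3 cells (Homo sapiens) for antiproliferative activity, read by MTT assay, tested at 1 uM; a lower number here means a weaker effect, a higher number a stronger effect of the compound at the concentration tested:

Compound 1, `COc1cc(C2=NN(C(C)=O)C(c3cc(Cl)cc(Cl)c3)O2)cc(OC)c1OC`, gives 52.7%
Compound 2, `COc1cc(C2=NN(C(C)=O)C(c3cccc(OC)c3OC)O2)cc(OC)c1OC`, gives 35%
Compound 3, `COc1cc(C2=NN(C(C)=O)C(c3ccccc3F)O2)cc(OC)c1OC`, gives 13.5%

Compound 3 stands lowest of the three in this assay. Its nearest neighbour is compound 2, and the gap a number 21.5 percentage points lower from compound 2 to compound 3 (beyond the scatter) lies beyond the scatter; the gap to compound 1, a number 39.2 percentage points lower from compound 1 to compound 3 (beyond the scatter), is larger still. All three compounds share one core and differ only in the aryl group on the saturated ring carbon, so every measured step is an aryl swap at the same place.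

Compound 4, `COc1cc(C2=NN(C(C)=O)C(c3cccc(C(F)(F)F)c3)O2)cc(OC)c1OC`, has not yet been measured. It differs from compound 3 as follows: 3-(trifluoromethyl)phenyl in place of 2-fluorophenyl on a saturated ring carbon

Going by the values given here, the steps that bear on this change are the aryl swaps already seen. Replacing 3,5-dichlorophenyl by 2,3-dimethoxyphenyl gave a number 17.7 percentage points lower from compound 1 to compound 2 (beyond the scatter), and replacing it by 2-fluorophenyl gave a number 39.2 percentage points lower from compound 1 to compound 3 (beyond the scatter); the step of a number 21.5 percentage points lower from compound 2 to compound 3 (beyond the scatter) was modest. Since compound 3 sits at the bottom, a step upward in this assay is expected for compound 4, most likely of moderate size, landing between the values of compound 3 and compound 1. The expected step is a number 24.5 percentage points higher from compound 3 to compound 4 (beyond the scatter). For compound 4 the estimate is 38%, with a range from 18% to 58%.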

Compound 4, a percentage reported as inhibition, at one concentration (the size of the read-out at that concentration, not a potency): 30.1%
Estimate against measurement, compound 4: 7.9 percentage points above, and the stated range covers the measured number.
By their numbers in this assay, from the lowest: compound 3; then compounds 4 and 2 (each within the scatter of the next); then compound 1.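

In this assay, the two fluorine-bearing aryl groups do not behave alike on the saturated ring carbon: 3-(trifluoromethyl)phenyl in place of 2-fluorophenyl gives (a number 16.6 percentage points higher from compound 3 to compound 4 (beyond the scatter)), so the presence of fluorine on the aryl group does not by itself set the read-out among these compounds. The same group cannot be told apart from the quite different 2,3-dimethoxyphenyl (a number 4.9 percentage points lower from compound 2 to compound 4 (within the scatter)), yet it remains clearly short of 3,5-dichlorophenyl (a number 22.6 percentage points lower from compound 1 to compound 4 (beyond the scatter)), which now stands as the highest of four compounds rather than of three. Nothing measured here explains why these aryl groups differ.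

The aryl groups shown carry only fluoro, trifluoromethyl, chloro or methoxy substituents, so it remains open how an aryl group bearing an amine or a carboxylic acid would fare at this position. Each compound is also read at a single concentration, which leaves open whether the same order would hold at other concentrations.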